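From methoxy to trifluoromethoxy: notes on compound 4

A few compounds are considered here, and "the series" means these few. Any claim that something is new, unique, unknown or untested is made for them only; others in the source may bear on it.

Measured in a functional assay on A549 cells (Homo sapiens) for antiproliferative activity, read by MTT assay; a lower number here means a stronger inhibitor, a higher number a weaker inhibitor:
- Compound 1 `Cn1c(=O)c(=O)n(C2CCCC2)c2nc(N/N=C/c3ccccc3)ncc21`: > 100000 nM, a limit.
- Compound 2 `Cn1c(=O)c(=O)n(C2CCCC2)c2nc(N/N=C/c3ccc(C(F)(F)F)cc3)ncc21`: 40600 nM.
- Compound 3 `COc1ccc(/C=N/Nc2ncc3c(n2)n(C2CCCC2)c(=O)c(=O)n3C)cc1`: > 100000 nM, a limit.

Compound 3 gives no number and sits at the limit of > 100000 nM in this assay, at which 2 of the 3 values shown sit. Compound 4 `Cn1c(=O)c(=O)n(C2CCCC2)c2nc(N/N=C/c3ccc(OC(F)(F)F)cc3)ncc21` differs from it by trifluoromethyl in place of methyl on an oxygen on an aromatic ring, which reads as methoxy to trifluoromethoxy. For the measured compounds named here, two measured steps bear on this: an at least 2.4-fold lower number from compound 1 to compound 2 (0.39 log units; beyond the scatter) and an at least 2.4-fold higher number from compound 2 to compound 3 (0.39 log units; beyond the scatter). The third is a step that the two limits leave unreadable from compound 1 to compound 3. Of the three compounds, only compound 2, with its trifluoromethyl, reaches a readable value, 40600 nM. A modest move to a lower number in this assay is therefore expected, though compound 4 may stay at the limit. The expected change is an at least 2.2-fold lower number from compound 3 to compound 4 (0.34 log units; beyond the scatter). For compound 4 the estimate is 45000 nM, with an expected range of 15000 nM to 100000 nM.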

Compound 4, half-maximal inhibitory concentration: 12900 nM
Beside the measured number, compound 4's estimate is 3.5-fold (0.54 log units) above it, and the stated range ends above it.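

In this assay trifluoromethyl in place of methyl on the oxygen gives an at least 7.7-fold lower number from compound 3 to compound 4 (0.88 log units; beyond the scatter) and turns a limit into a readable value. Trifluoromethoxy also separates from trifluoromethyl, with a 3.1-fold lower number from compound 2 to compound 4 (0.50 log units; beyond the scatter) as the only new step between two readable values, so these two fluorinated groups are not interchangeable on this ring. Against hydrogen the change is an at least 7.7-fold lower number from compound 1 to compound 4 (0.88 log units; beyond the scatter) and, like the step from methoxy, it stays a bound, since one end of it is a limit: the limit of > 100000 nM in this assay, at which 2 of the 4 values shown sit.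

Open, as far as these compounds go, is whether an amine, a carboxylic acid or a longer chain in this place would give a readable value. Also open, from the compounds shown here alone, is whether any group on this ring reaches a lower number than compound 4 gives.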